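The source may hold more compounds than are shown below. What is called first, only, known or untested is meant among the compounds shown, and "the series" means these compounds.

Compound 1 `Cn1nc2c(=O)n(CC3(O)CCN(Cc4ccc(-c5ccco5)cc4Cl)CC3)cnc2c1-c1ccc(CNC(=O)C(F)(F)F)cc1`, compound 2 `Cn1nc2c(=O)n(CC3(O)CCN(Cc4ccc(-c5ccncc5)cc4Cl)CC3)cnc2c1-c1ccc(CN)cc1` and compound 3 `Cn1nc2c(=O)n(CC3(O)CCN(Cc4ccc(-c5ccco5)cc4Cl)CC3)cnc2c1-c1ccc(C(N)=O)cc1` share one core and differ from one another in two places. In an assay on isolated protein for inhibition of ubiquitin carboxyl-terminal hydrolase 7 (Homo sapiens), with stated times of 30 min and 2 h (a lower number here means a stronger inhibitor, a higher number a weaker inhibitor), compound 1 gives 2060 nM, compound 2 gives 257 nM and compound 3 gives 80.8 nM, so compound 2 stands between the other two, nearer to compound 3. For the measured compounds named here, the only single-point step known, a 25-fold lower number from compound 1 to compound 3 (1.41 log units; beyond the scatter), concerns the carbamoyl group and not the ring exchanged here. Compound 4 `Cn1cc(-c2ccc(CN3CCC(O)(Cn4cnc5c(-c6ccc(CN)cc6)n(C)nc5c4=O)CC3)c(Cl)c2)cn1` arises from compound 2 by 1-methyl-1H-pyrazol-4-yl in place of pyridin-4-yl on an aromatic carbon. Going by the values given here, no measured step bears on this exchange; compounds 2 and 3 differ at that ring but also between aminomethyl and carbamoyl, so their gap cannot be assigned. A step of no size beyond the scatter is therefore expected in this assay, a 1.0-fold higher number from compound 2 to compound 4 (0.01 log units; within the scatter). Compound 4 is estimated at 260 nM, within 100 nM to 700 nM.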

Compound 4, half-maximal inhibitory concentration: 291 nM
Compound 4: the middle estimate sits 1.1-fold (0.05 log units) below what was measured; the range from low to high includes it.
By their numbers in this assay, from the lowest: compound 3; then compounds 2 and 4 (each within the scatter of the next); then compound 1.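

In this assay the first step read at this position is a 1.1-fold higher number from compound 2 to compound 4 (0.05 log units; within the scatter) with 1-methyl-1H-pyrazol-4-yl in place of pyridin-4-yl, on an aromatic carbon para to a large group. With aminomethyl on the other side of the shared core, a five-membered aromatic ring with 2 hetero atoms therefore reads the same as a six-membered aromatic ring with 1 hetero atom. No measured evidence on either ring accompanies this result.

Open, as far as these compounds go, is how a phenyl group would compare at this position. Also open, from the compounds shown here alone, is whether an ethyl group in place of the methyl on the 1-methyl-1H-pyrazol-4-yl ring would shift the number.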